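The source may report more compounds than this note shows. Statements on the series, on what has been measured and on what is new or still open speak of the compounds shown alone.

The series is a set of acrylonitriles tested in a functional assay on MIA cells (Homo sapiens) for inhibition, read by MTT assay, with a stated time of 72 h; on this read-out higher numbers stand for weaker inhibition of growth and lower numbers for stronger inhibition of growth. Compound 1 `N#C/C(=C\c1ccc(Cl)cc1)C(=O)c1ccc[nH]1` gives 48000 nM. Compound 2 `N#C/C(=C\c1c(F)c(F)c(F)c(F)c1F)C(=O)c1ccc[nH]1` gives 25000 nM. Compound 3 `COc1ccc(CNC(=O)/C(C#N)=C/c2ccc[nH]2)cc1` differs from both in carrying an amide rather than a ketone and in placing the pyrrole on the alkene, and in this assay compound 3 is recorded only as a limit, > 50000 nM, so no number stands for it. That places compound 3 at the limit of > 50000 nM in this assay, at which 1 of the 3 values shown sits, the weak end of everything shown here.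

Compound 4 `COc1ccc(CNC(=O)/C(C#N)=C/c2cc(Br)co2)cc1` has not yet been measured. It differs from compound 3 by a single exchange, (4-bromofuran-2-yl in place of 1H-pyrrol-2-yl on a double-bonded chain carbon bound to a double-bonded chain carbon). For the measured compounds named here, no pair of measured compounds shows the effect of such an exchange, so the step must be guessed from the position of compound 3 alone.

Since compound 3 gives only a limit in this assay, the step of an at least 1.2-fold lower number from compound 3 to compound 4 (0.09 log units; that floor lies within the scatter) is expected to be modest and uncertain in direction, and there is a fair chance that compound 4 too will come back as a limit. Compound 4 is estimated at 40000 nM in this assay, with a plausible range from 10000 nM to 100000 nM.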

Compound 4, concentration for 50% growth inhibition: 65000 nM
Compound 4: the middle estimate sits 1.6-fold (0.21 log units) below what was measured; low and high end bracket the measured number.
By their numbers in this assay, from the lowest: compounds 2, 1 and 4 (each within the scatter of the next, the first and the last beyond it).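

In this assay, for the compounds shown here, compound 3 stands only as a limit, so no step from it to compound 4 can be read: the limit of > 50000 nM in this assay, at which 1 of the 4 values shown sits. The compounds shown leave open how far 4-bromofuran-2-yl in place of 1H-pyrrol-2-yl shifts inhibition of growth, with no pair of numbers carrying that exchange.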